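Aminophenyl Sulfonamide Tested Against DLD-1 Cell Growth

This account rests on a few compounds, and the source may have more. Where it says the series, first, only, none or still open, it means among the compounds named here.

Measured so far:
- compound 1 `CC1CCN(C2CCN(S(=O)(=O)c3cccc(C(F)(F)F)c3)CC2)CC1`: > 5000 nM
- compound 2 `CC1CCN(C2CCN(S(=O)(=O)c3cccnc3Cl)CC2)CC1`: > 5000 nM
- compound 3 `CC1CCN(C2CCN(S(=O)(=O)c3ccc(C#N)cc3)CC2)CC1`: 2800 nM

In a functional assay on DLD-1 cells (Homo sapiens) for antiproliferative activity, read by CellTiter-Glo, with a stated time of 72 h (on this read-out lower numbers stand for stronger inhibition and higher numbers for weaker inhibition), compound 1 gives > 5000 nM, which is a limit of the assay rather than a number. Compound 2 likewise gives > 5000 nM, again only a limit. For the measured compounds named here, compound 3 gives 2800 nM, the only true number among the three, so it is the one point from which any further step can be judged. Going by the values given here, the single measured step, an at least 1.7-fold lower number from compound 2 to compound 3 (0.25 log units; that floor lies within the scatter), is modest, and its floor lies within the scatter (the limit of > 5000 nM in this assay, at which 2 of the 3 values shown sit).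

Compound 4 `CC1CCN(C2CCN(S(=O)(=O)c3cccc(N)c3)CC2)CC1` differs from compound 3 by 3-aminophenyl in place of 4-cyanophenyl on a sulfonyl sulfur. Among the compounds with values here, no measured step involves an aminophenyl group, so the only guidance is that two aryl variants sat at the limit while the nitrile variant gave a number just inside the measurable range. Compound 4 is therefore expected to land near compound 3 or somewhat weaker, a step of a 1.4-fold higher number from compound 3 to compound 4 (0.15 log units; within the scatter) that is not clearly beyond the scatter. The estimate for compound 4 is 4000 nM, within a range of 1200 nM to 15000 nM, with a real chance that only a limit is reported.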

Compound 4, half-maximal inhibitory concentration: 3400 nM
Beside the measured number, compound 4's estimate is 1.2-fold (0.07 log units) above it; the measured number falls inside the stated range.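

In this assay, 3-aminophenyl on the sulfonyl sulfur gives a true number just as 4-cyanophenyl does, and the change is a 1.2-fold higher number from compound 3 to compound 4 (0.08 log units; within the scatter), so the nitrile is not required for a measurable value and the two compounds cannot be told apart. Against the two compounds that sit at the limit, the comparisons are an at least 1.4-fold lower number from compound 1 to compound 4 (0.16 log units; that floor lies within the scatter) and an at least 1.4-fold lower number from compound 2 to compound 4 (0.16 log units; that floor lies within the scatter). Neither comparison shows a firm gain for the amino compound, because each starts from a value that is only a limit and gives only a floor within the scatter: the limit of > 5000 nM in this assay, at which 2 of the 4 values shown sit.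

Going by these compounds, whether a carboxylic acid or a methoxy group on the aromatic ring would move the number beyond the scatter remains open. The compounds shown also keep the rest of the core unchanged, so what that part contributes is unknown.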